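The source may hold more compounds than are shown below. What is called first, only, known or untested is meant among the compounds shown, and "the series" means these compounds.

Compound 1, `Cc1ccc(/C=C2\CCCC(C)C2=O)cc1`: > 30000 nM
Compound 2, `CC1CCC/C(=C\c2ccc(Cl)cc2)C1=O`: > 30000 nM

In a functional assay on B16 cells (Mus musculus) for inhibition, with a stated time of 3 days (on this read-out lower numbers stand for stronger inhibition and higher numbers for weaker inhibition), compound 1 gives > 30000 nM, which is a limit of the assay rather than a measured number. Compound 2 gives > 30000 nM in this assay, again a limit. For the measured compounds named here, compound 2 thus stands at the same limit as compound 1, and the single measured step, a step that the two limits leave unreadable from compound 1 to compound 2, cannot be read in size or direction, since both values sit at the limit of > 30000 nM in this assay, at which 2 of the 2 values shown sit. Compound 3, `COc1ccc(/C=C2\CCCC(C)C2=O)cc1`, differs from compound 2 by methoxy in place of chloro on an aromatic carbon. Going by the values given here, no measured step bears on this particular change, and the one step that is known is unreadable, so nothing points to a shift beyond the scatter in this assay. For compound 3 the expected step is a step that the limit leaves unreadable from compound 2 to compound 3, meaning no readable change. The estimated value for compound 3 is 40000 nM, with a range from 12000 nM to 150000 nM, most likely reported again only as a limit.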

Compound 3, half-maximal inhibitory concentration: > 30000 nM
Compound 3: a limit, no number (the forecaster's own chance of this, stated with the estimate: 80%); the middle value lies beyond the limit too.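

The result for compound 3 is also a limit rather than a number, so the steps linking compound 1, compound 2 and compound 3 cannot be read in size or direction: the limit of > 30000 nM in this assay, at which 3 of the 3 values shown sit. The compounds shown leave open how methyl, chloro and methoxy on the aromatic carbon compare, and whether any change to the shared core gives a measured number in this assay.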